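This account rests on a few compounds, and the source may have more. Where it says the series, first, only, none or still open, it means among the compounds named here.

Measured compounds in an assay on isolated protein for displacement of a labelled ligand from Apoptosis regulator Bcl-2 (Homo sapiens), with a stated time of 15 min; a lower number here means a stronger inhibitor, a higher number a weaker inhibitor:
- compound 1 `CN(C)CCCNc1ccc(S(=O)(=O)NC(=O)c2ccc(N3CCN(CC4=C(c5ccc(C(F)(F)F)cc5)CC(C)(C)CC4)CC3)cc2Oc2cnc3[nH]ccc3c2)cc1[N+](=O)[O-]` gives 0.89 nM
- compound 2 `CN1CCC(CNc2ccc(S(=O)(=O)NC(=O)c3ccc(N4CCN(CC5=C(c6ccc(C(F)(F)F)cc6)CC(C)(C)CC5)CC4)cc3Oc3cnc4[nH]ccc4c3)cc2[N+](=O)[O-])C1` gives 2.4 nM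
- compound 3 `CC1(C)CCC(CN2CCN(c3ccc(C(=O)NS(=O)(=O)c4ccc(OC5CCOCC5)c([N+](=O)[O-])c4)c(Oc4cnc5[nH]ccc5c4)c3)CC2)=C(c2ccc(C(F)(F)F)cc2)C1` gives 8.4 nM

Compound 3 holds the highest number of the three. The step from compound 2 to compound 3 is a 3.5-fold higher number from compound 2 to compound 3 (0.54 log units; beyond the scatter) and from compound 1 to compound 3 is a 9.4-fold higher number from compound 1 to compound 3 (0.97 log units; beyond the scatter); both go beyond the usual scatter, so compound 3 is the weakest of the measured set in this assay.

Compound 4 `CC1(C)CCC(CN2CCN(c3ccc(C(=O)NS(=O)(=O)c4ccc(OCC5CCOC5)c([N+](=O)[O-])c4)c(Oc4cnc5[nH]ccc5c4)c3)CC2)=C(c2ccc(C(F)(F)F)cc2)C1` differs from compound 3 only at the ether on the aromatic ring: (oxolan-3-yl)methyl in place of oxan-4-yl on an oxygen on an aromatic ring. The two compounds have the same atoms joined differently.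

Within the data shown here, none of the measured steps tests this kind of change. The step from compound 1 to compound 2, a 2.7-fold higher number from compound 1 to compound 2 (0.43 log units; beyond the scatter), and the two steps into compound 3 all swap an amine-bearing side chain for a neutral ether; here one neutral ether is traded for another of the same size. Among the measured compounds shown here, with no direct precedent, the expected step in this assay is small, and no direction is favoured beyond the scatter.

The estimate for compound 4 is therefore 10 nM, with a range from 4 nM to 25 nM, a step of a 1.2-fold higher number from compound 3 to compound 4 (0.08 log units; within the scatter) that is expected to stay within the scatter.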

Compound 4, half-maximal inhibitory concentration: 4.4 nM
Estimate against measurement, compound 4: 2.3-fold (0.36 log units) above; the measured number falls inside the stated range.
By their numbers in this assay, from the lowest: compound 1; then compounds 2, 4 and 3 (each within the scatter of the next, the first and the last beyond it).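

In this assay, moving the same atoms from oxan-4-yl to (oxolan-3-yl)methyl, on an oxygen on an aromatic ring, gives a 1.9-fold lower number from compound 3 to compound 4 (0.28 log units; within the scatter), so this position shows no measurable preference between the six-membered ring and the five-membered ring on its short chain. Compound 4, with no amine in this side chain, also cannot be told apart from the amine-bearing compound 2, at a 1.8-fold higher number from compound 2 to compound 4 (0.26 log units; within the scatter), while the gap to the dimethylamino chain remains real at a 4.9-fold higher number from compound 1 to compound 4 (0.69 log units; beyond the scatter), so here a neutral ether is weaker than that one amine side chain but not clearly weaker than the other. No measurement shown here offers an explanation for these numbers.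

The step to compound 4 changes the ring and its attachment together, so a direct comparison using (oxan-4-yl)methyl on the same oxygen would be needed to separate the two changes. Also open, as far as these compounds go, is whether a nitrogen link carrying the oxan-4-yl ring, or a dimethylamino group placed on the oxolane ring, would close the remaining gap to compound 1.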